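Aryl variation in quinoline thiosemicarbazones on colon carcinoma cells

The compounds below may be only part of what the source reports. "The series", "measured", "known", "first", "only" and "open" are said of these compounds alone.

Compound 1 `Fc1ccccc1NC(=S)N/N=C/c1ccc2ccccc2n1`, compound 2 `S=C(NCc1ccccc1)N/N=C/c1ccc2ccccc2n1` and compound 3 `COc1cccc(NC(=S)N/N=C/c2ccc3ccccc3n2)c1` share one core and differ only in the group on the amide-type nitrogen. In a functional assay on HT-29 cells (Homo sapiens) for antiproliferative activity, read by sulforhodamine B assay, with a stated time of 72 h (on this read-out higher numbers stand for weaker inhibition and lower numbers for stronger inhibition), compound 1 reaches only the limit > 100000 nM. In this assay compound 2 gives 75700 nM, while compound 3 gives 82400 nM, so that compound 3 stands beside compound 2, since a 1.1-fold higher number from compound 2 to compound 3 (0.04 log units; within the scatter) lies within the scatter. Compound 4 `Cc1ccccc1NC(=S)N/N=C/c1ccc2ccccc2n1` differs from compound 3 by 2-methylphenyl in place of 3-methoxyphenyl on an amide-type nitrogen. Among the measured compounds shown here, the steps that bear on this exchange, an at least 1.2-fold lower number from compound 1 to compound 3 (0.08 log units; that floor lies within the scatter) and a 1.1-fold higher number from compound 2 to compound 3 (0.04 log units; within the scatter), both stay within the scatter, so no step beyond the scatter is expected in this assay. Compound 4 is therefore estimated at 85000 nM, between 40000 nM and 180000 nM, an expected step of a 1.0-fold higher number from compound 3 to compound 4 (0.01 log units; within the scatter).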

Compound 4, half-maximal inhibitory concentration: 42300 nM
Compound 4: the middle estimate sits 2.0-fold (0.30 log units) above what was measured; low and high end bracket the measured number.
By their numbers in this assay, from the lowest: compounds 4, 2 and 3 (each within the scatter of the next). At a limit, above all of these: compound 1.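

In this assay, among the compounds shown here, the exchange of fluoro for methyl on an aromatic carbon gives the one step at this position that passes the scatter, an at least 2.3-fold lower number from compound 1 to compound 4 (0.37 log units; beyond the scatter), and this is only a floor, since compound 1 stands at a limit: the limit of > 100000 nM in this assay, at which 1 of the 4 values shown sits. Against the other groups, 2-methylphenyl stays within the scatter, with a 1.9-fold lower number from compound 3 to compound 4 (0.29 log units; within the scatter) and a 1.8-fold lower number from compound 2 to compound 4 (0.25 log units; within the scatter), so these three groups are not separated. Still open, from the compounds shown here alone, is whether an amine or a carboxylic acid on the aromatic ring, or a longer chain on the amide-type nitrogen, would move the number clear of the scatter.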